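Swapping the triazole ring for a tetrazole in the thioether

The source may report more compounds than this note shows. Statements on the series, on what has been measured and on what is new or still open speak of the compounds shown alone.

Two analogues sharing one core have been measured. Compound 1 `Cn1c(-c2ccc(NC(=O)CSc3nc4cc(Cl)ccc4o3)cc2)nc(-c2ccccc2)c1-c1ccccc1` gives 17.4% in a functional assay on HT-29 cells (Homo sapiens) for cytotoxicity, read by MTT assay, with a stated time of 24 h, tested at 1.6 ug/mL; on this read-out higher numbers stand for a stronger effect at the one concentration tested and lower numbers for a weaker effect. Among the measured compounds shown here, compound 2 `Cn1cnnc1SCC(=O)Nc1ccc(-c2nc(-c3ccccc3)c(-c3ccccc3)n2C)cc1` gives 40.8% in this assay, and that puts compound 2 highest of the two numbers, the single step of a number 23.4 percentage points higher from compound 1 to compound 2 (beyond the scatter) lying beyond the scatter.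

Compound 3 `Cn1nnnc1SCC(=O)Nc1ccc(-c2nc(-c3ccccc3)c(-c3ccccc3)n2C)cc1` has not yet been measured. Its difference from compound 2 is 1-methyl-1H-tetrazol-5-yl in place of 4-methyl-4H-1,2,4-triazol-3-yl on a sulfur. For the measured compounds named here, no measured step bears directly on this exchange: the one step on record, a number 23.4 percentage points higher from compound 1 to compound 2 (beyond the scatter), replaced a much larger bicyclic group with the triazole, whereas here one small five-membered ring gives way to another of the same size. On that basis the expected step of a number 2.8 percentage points lower from compound 2 to compound 3 (within the scatter) is small, not beyond the scatter in either direction. Compound 3 is therefore estimated to give 38% in this assay, within a range from 22% to 55%.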

Compound 3, a percentage reported as activity, at one concentration (the size of the read-out at that concentration, not a potency): 49.8%
For compound 3 the middle estimate is 11.8 percentage points below the measured one; the measured number falls inside the stated range.
By their numbers in this assay, from the lowest: compound 1; then compounds 2 and 3 (each within the scatter of the next).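

At the place on a sulfur whose other neighbour is a saturated chain carbon, putting 1-methyl-1H-tetrazol-5-yl in place of 4-methyl-4H-1,2,4-triazol-3-yl gives a number 9 percentage points higher from compound 2 to compound 3 (within the scatter) in this assay, so these two small rings cannot be told apart on this read-out. The gain over 5-chloro-1,3-benzoxazol-2-yl is also no longer tied to the triazole alone, since the tetrazole gives a number 32.4 percentage points higher from compound 1 to compound 3 (beyond the scatter). No measurement offered here accounts for either step.

As far as these compounds go, it remains open whether the ring on the sulfur is needed at all, or whether a carboxylic acid or an amine in that place would give a comparable number. Also open, from the compounds shown here alone, is how an ethyl group in place of the methyl on either small ring would read.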